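From Chloro to Methoxy at the Assay Limit

A few compounds are considered here, and "the series" means these few. Any claim that something is new, unique, unknown or untested is made for them only; others in the source may bear on it.

Compound 1 `COc1cc(-c2ncnn2-c2cccc(F)c2)cc(OC)c1OC`: > 10000 nM (a limit)
Compound 2 `COc1cc(-c2ncnn2-c2cccc(N)c2)cc(OC)c1OC`: > 10000 nM (a limit)
Compound 3 `COc1cc(-c2ncnn2-c2ccc(Cl)cc2)cc(OC)c1OC`: > 10000 nM (a limit)

These three compounds were tested in a functional assay on K562 cells (Homo sapiens) for antiproliferative activity, read by MTT assay, with a stated time of 72 h; on this read-out higher numbers stand for weaker inhibition and lower numbers for stronger inhibition. Compound 3 gives > 10000 nM, which is a limit of the measurement and not a number. It therefore has no exact place on the scale, and the same is true of the other two compounds.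

Compound 4 `COc1ccc(-n2ncnc2-c2cc(OC)c(OC)c(OC)c2)cc1` differs from compound 3 in one place, with methoxy in place of chloro on an aromatic carbon, para to a large group: methoxy in place of chloro on an aromatic carbon. Among the measured compounds shown here, no measured step makes this same exchange. The nearest comparisons for compound 3 are a step that the two limits leave unreadable from compound 1 to compound 3 and a step that the two limits leave unreadable from compound 2 to compound 3, while the remaining pair gives a step that the two limits leave unreadable from compound 1 to compound 2. All that the data show is the limit of > 10000 nM in this assay, at which 3 of the 3 values shown sit. None of these steps provides a size to carry over, so any expectation here is loose.

The estimate means an at least 2.0-fold lower number from compound 3 to compound 4 (0.30 log units; that floor lies within the scatter), an expected step of uncertain size towards stronger inhibition. Another reading at the limit is also expected to be quite possible. Compound 4 is estimated at 5000 nM, with an expected range from 300 nM to 20000 nM.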

Compound 4, half-maximal inhibitory concentration: 3600 nM
Compound 4: middle estimate off by 1.4-fold (0.14 log units), on the high side; the range from low to high includes it.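

In this assay, among the compounds shown here, methoxy in place of chloro on an aromatic carbon, para to a large group, gives the first step here with a readable lower bound: an at least 2.7-fold lower number from compound 3 to compound 4 (0.44 log units; beyond the scatter). Compound 3 gives > 10000 nM, which is a limit and not a number, so this figure is a minimum and the true step may be larger. For the compounds shown here, the comparisons with the other two compounds are also minimums, an at least 2.7-fold lower number from compound 2 to compound 4 (0.44 log units; beyond the scatter) and an at least 2.7-fold lower number from compound 1 to compound 4 (0.44 log units; beyond the scatter), while the steps among compounds 1, 2 and 3 cannot be read, leaving compound 4 as the only compound with an exact value: the limit of > 10000 nM in this assay, at which 3 of the 4 values shown sit.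

The compounds shown leave open whether ethoxy, hydroxy or an amine in this same place would also give a value below the limit, and how such a value would compare with that of compound 4. Going by these compounds alone, with only one exact value, they also cannot show how much stronger inhibition could become through changes at this place, or whether the result with methoxy would carry over to a different group elsewhere on the shared core.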